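Chloro to methoxy: one swap on compound 2

A few compounds are considered here, and "the series" means these few. Any claim that something is new, unique, unknown or untested is made for them only; others in the source may bear on it.

Measured in a functional assay on HL-60 cells (Homo sapiens) for inhibition, read by MTT assay, with a stated time of 72 h; a lower number here means a stronger inhibitor, a higher number a weaker inhibitor:
Compound 1 `CCc1nc(-c2ccc(C(C)C)cc2)c(C(=O)N2CCN(c3cccc(OC)c3)CC2)o1`: 887 nM
Compound 2 `CCc1nc(-c2cccc(F)c2)c(C(=O)N2CCN(c3cccc(Cl)c3)CC2)o1`: 317 nM

Of these two, compound 2 has the lower number and is the stronger inhibitor, and the gap to compound 1 lies beyond the usual scatter. The two differ in more than one place, so that gap cannot be pinned on any single group.

Compound 3 `CCc1nc(-c2cccc(F)c2)c(C(=O)N2CCN(c3cccc(OC)c3)CC2)o1` is not yet measured. It differs from compound 2 in one place, with methoxy in place of chloro on an aromatic carbon. Among the measured compounds shown here, no measured pair isolates this swap. For the measured compounds named here, the only hint is compound 1, which also carries 3-methoxyphenyl and reads 887 nM.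

In this assay a small weakening is expected, an estimated 1.5-fold higher number from compound 2 to compound 3 (0.18 log units; within the scatter), which may stay within the usual scatter. For compound 3 the expected value is 480 nM, with an estimated range of 170 nM to 1300 nM.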

Compound 3, half-maximal inhibitory concentration: 201 nM
For compound 3 the middle estimate is 2.4-fold (0.38 log units) above the measured one, within the range that was stated.
By their numbers in this assay, from the lowest: compounds 3 and 2 (each within the scatter of the next); then compound 1.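

In this assay, the swap from 3-chlorophenyl to 3-methoxyphenyl can now be read on its own, and a 1.6-fold lower number from compound 2 to compound 3 (0.20 log units; within the scatter) shows that the two groups cannot be told apart at this position. Compound 3 also forms a one-place pair with compound 1, and a 4.4-fold lower number from compound 1 to compound 3 (0.64 log units; beyond the scatter) places a step beyond the scatter on the change from 4-isopropylphenyl to 3-fluorophenyl, so the methoxy group is shared and this other ring substituent is what separates those two compounds. Nothing at hand explains either step.

Going by these compounds, whether a larger change at this position, such as an amine or a carboxylic acid in place of methoxy, would move the number beyond the scatter stays open. Also open, on these data alone, is how a lone fluoro or isopropyl change would read, since the step from compound 1 to compound 3 alters both together.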